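One ring stereocentre changed from compound 2 to compound 3

A few compounds are considered here, and "the series" means these few. Any claim that something is new, unique, unknown or untested is made for them only; others in the source may bear on it.

In a physicochemical assay for acid dissociation, compound 1 (`CN1CC[C@H]2CCC[C@@H](NC(=O)c3ccccc3)[C@H]2C1`) gives 9.18 and compound 2 (`COc1ccccc1C(=O)N[C@@H]1CCC[C@@H]2CCN(C)C[C@H]21`) gives 8.81 as the lower of the two numbers, a gap beyond the usual scatter. Compound 3 (`COc1ccccc1C(=O)N[C@@H]1CCC[C@@H]2CCN(C)C[C@@H]21`) differs from compound 2 (the two compounds have the same atoms and bonds and differ only in configuration as drawn: 1 of 3 stereo elements differ; a stereocentre at a saturated ring carbon is drawn S in compound 2 and R in compound 3) in that a stereocentre at a saturated ring carbon is drawn S in compound 2 and R in compound 3. For the measured compounds named here, no measured pair isolates such a change. The estimated a number 0.09 log units higher from compound 2 to compound 3 (within the scatter) is expected to be a small rise, not beyond the scatter. For compound 3 the estimated value is 8.9 with an expected range of 8.5 to 9.3 for this measurement.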

Compound 3, acid dissociation constant: 9.11
Beside the measured number, compound 3's estimate is 0.21 log units below it, and the stated range covers the measured number.
By their numbers in this assay, from the lowest: compounds 2, 3 and 1 (each within the scatter of the next, the first and the last beyond it).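

In this assay, this saturated ring carbon gives the first single-place stereo step, a number 0.30 log units higher from compound 2 to compound 3 (within the scatter), so drawing it R rather than S moves the number by no more than the scatter. For the compounds shown here, the only structural reading available for this pair is configuration: the fact that compounds 2 and 3 differ only in the configuration as drawn The other single-place step, methoxy in place of hydrogen on an aromatic carbon, is a number 0.07 log units lower from compound 1 to compound 3 (within the scatter), also without a shift beyond the scatter. From the compounds shown here alone, the other two stereo elements remain open. So does whether a nitrile or a dimethylamino group in place of methoxy would give a step beyond the scatter.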